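Sulfonamide amine swap on the alkyne-linked phenoxyacetic acid series

This account rests on a few compounds, and the source may have more. Where it says the series, first, only, none or still open, it means among the compounds named here.

Compound 2 `COCCN(C)S(=O)(=O)c1ccc(C)c(C#Cc2cc(Cl)ccc2OCC(=O)O)c1` gives 4.1 nM in an assay on CHO cells for displacement of a labelled ligand from prostaglandin D2 receptor 2 (Homo sapiens), read by scintillation counting (a higher number here means a weaker inhibitor, a lower number a stronger inhibitor), the lowest number of the three measured. Compound 1 `CC(C)c1ccc(S(C)(=O)=O)cc1C#Cc1cc(C#N)ccc1OCC(=O)O` gives 12 nM in this assay, and compound 3 `COCc1ccc(F)c(C#Cc2cc(Cl)ccc2OCC(=O)O)c1` gives 72 nM; both steps up from compound 2 lie beyond the scatter. Compound 4 `Cc1ccc(S(=O)(=O)N2CCN(C)CC2)cc1C#Cc1cc(Cl)ccc1OCC(=O)O` carries 4-methylpiperazin-1-yl in place of (2-methoxyethyl)(methyl)amino on a sulfonyl sulfur. For the measured compounds named here, no measured pair shows this exact exchange, so no step size is known from the data. Since the change sits on a sulfonyl group away from the acid-bearing core, and compound 2 is at 4.1 nM, the estimated step from compound 2 to compound 4 is a 1.5-fold higher number from compound 2 to compound 4 (0.17 log units; within the scatter), expected to fall within the scatter or only slightly toward a weaker inhibitor. Compound 4 is estimated at 6 nM, with a range from 2 nM to 20 nM.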

Compound 4, inhibition constant: 21 nM
For compound 4 the middle estimate is 3.5-fold (0.54 log units) below the measured one; measured number above the stated range.
By their numbers in this assay, from the lowest: compound 2; then compounds 1 and 4 (each within the scatter of the next); then compound 3.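

The amine on the sulfonyl sulfur is not a silent part of these molecules: 4-methylpiperazin-1-yl in place of (2-methoxyethyl)(methyl)amino gives a 5.1-fold higher number from compound 2 to compound 4 (0.71 log units; beyond the scatter). For the compounds shown here, this is the first one-place pair, and here the open chain carries the lower number. Nothing shown explains the size of this step.

The compounds shown leave open whether the step follows from the ring itself or from its methyl-bearing nitrogen. A morpholin-4-yl or a dimethylamino group on the same sulfur would separate the two.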